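Anilide substituent variation in a triazole thioacetamide series

This account rests on a few compounds, and the source may have more. Where it says the series, first, only, none or still open, it means among the compounds named here.

Measured so far:
- compound 1 `Cc1cccc(NC(=O)CSc2nnc(-c3ccoc3C)n2Cc2ccco2)c1`, in a functional assay on CHO cells for antagonist activity at Orexin receptor type 2 (Homo sapiens), read by FLIPR and calcium flux (on this read-out lower numbers stand for stronger inhibition and higher numbers for weaker inhibition), compound 1 gives 50.1 nM
- compound 2 `COc1ccc(NC(=O)CSc2nnc(-c3ccoc3C)n2Cc2ccco2)cc1`, in this assay compound 2 gives 200 nM

Among the measured compounds shown here, compound 2 carries the highest of the two numbers measured; its only neighbour is compound 1, and the step of a 4.0-fold higher number from compound 1 to compound 2 (0.60 log units; beyond the scatter) is a modest loss beyond the scatter.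

Compound 3 `Cc1occc1-c1nnc(SCC(=O)Nc2ccc(N(C)C)cc2)n1Cc1ccco1` is the next candidate. Relative to compound 2 the change is dimethylamino in place of methoxy on an aromatic carbon, described in words as dimethylamino in place of methoxy on an aromatic carbon. For the measured compounds named here, no measured step exchanges these two groups at the same site; the one step available, a 4.0-fold higher number from compound 1 to compound 2 (0.60 log units; beyond the scatter), alters both the group and its position at once and therefore bears only indirectly. The pair of groups share the counted features of no ring, no donor and one acceptor, so no movement beyond the scatter is expected in either direction, with wide uncertainty.

Compound 3 is expected to come in at 250 nM, range 80 nM to 800 nM, corresponding to a step of a 1.3-fold higher number from compound 2 to compound 3 (0.10 log units; within the scatter) that is estimated to sit within the scatter.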

Compound 3, inhibition constant: 158 nM
Estimate against measurement, compound 3: 1.6-fold (0.20 log units) above, within the range that was stated.
By their numbers in this assay, from the lowest: compound 1; then compounds 3 and 2 (each within the scatter of the next).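

In this assay, among the compounds shown here, dimethylamino in place of methoxy on an aromatic carbon, para to a large group, gives a 1.3-fold lower number from compound 2 to compound 3 (0.10 log units; within the scatter) and so leaves the read-out unresolved between these two groups at this site, which the earlier pair could not show because its one step changed both group and position. For the compounds shown here, replacing 3-methylphenyl on the amide-type nitrogen with 4-(dimethylamino)phenyl gives a 3.2-fold higher number from compound 1 to compound 3 (0.50 log units; beyond the scatter) and, alongside a 4.0-fold higher number from compound 1 to compound 2 (0.60 log units; beyond the scatter), shows that compound 1 carries the lower number against both 4-substituted anilides, with no compound here going against that limited observation. Nothing available explains why methoxy and dimethylamino read alike or why both anilides stand apart from compound 1.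

Still open, from the compounds shown here alone, is whether the lower number of compound 1 belongs to the methyl group or to its place on the ring, as each step from compound 1 alters both together. Also open, going by these compounds, is how a primary amine or a carboxylic acid in place of dimethylamino on the same aromatic carbon would read, and whether the tolerance seen here extends beyond these two groups.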